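The source may report more compounds than this note shows. Statements on the series, on what has been measured and on what is new or still open speak of the compounds shown alone.

Compound 1 `COc1cc(Nc2nc(C#N)cc3c(C(C)C)n[nH]c23)cc(OC)c1OC`: 355 nM
Compound 2 `COc1cc(Nc2nc(Cl)cc3c(-c4ccccc4)n[nH]c23)cc(OC)c1OC`: 89.1 nM
Compound 3 `COc1cc(Nc2nccc3c(-c4ccccc4)n[nH]c23)cc(OC)c1OC`: 251 nM

In an assay on Flp-In-CHO cells for binding affinity to adenosine receptor A3 (Homo sapiens), using Schild analysis (a lower number here means tighter binding, a higher number weaker binding), compound 3 gives 251 nM, the second highest of the three numbers. Compound 1 gives 355 nM, which lies within the scatter of compound 3, whereas compound 2 gives 89.1 nM, a lower number beyond the scatter. Among the measured compounds shown here, the only single-feature step among the measured compounds is a 2.8-fold higher number from compound 2 to compound 3 (0.45 log units; beyond the scatter): stripping the chloro from that position made the number rise modestly.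

Compound 4 `COc1cc(Nc2nc(CN)cc3c(-c4ccccc4)n[nH]c23)cc(OC)c1OC` differs from compound 3 by aminomethyl in place of hydrogen on an aromatic carbon. This returns a group to the position that chloro occupied in compound 2. For the measured compounds named here, no measured step tests aminomethyl itself; compound 1 carries a nitrile at that position but also differs from compound 3 elsewhere, so its number is not a clean comparison. A small lowering of the number, or no change beyond the scatter, is expected, as a 1.4-fold lower number from compound 3 to compound 4 (0.14 log units; within the scatter), because a 2.8-fold higher number from compound 2 to compound 3 (0.45 log units; beyond the scatter) showed that an occupied position can give a lower number than a bare one. Compound 4 is therefore estimated at 180 nM, with a range from 50 nM to 600 nM.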

Compound 4, dissociation constant: 257 nM
Beside the measured number, compound 4's estimate is 1.4-fold (0.15 log units) below it; measured number inside the range.
By their numbers in this assay, from the lowest: compound 2; then compounds 3, 4 and 1 (each within the scatter of the next).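

In this assay, aminomethyl on this aromatic carbon gives a 1.0-fold higher number from compound 3 to compound 4 (0.01 log units; within the scatter), so this group shows no real difference from the bare hydrogen. Aminomethyl in place of chloro gives a 2.9-fold higher number from compound 2 to compound 4 (0.46 log units; beyond the scatter), which shows that filling this position is not enough on its own: of the three groups compared here, only chloro gives the lower number, and what matters is which group sits there. No measurement shown here explains why chloro and aminomethyl differ.

The nitrile of compound 1 cannot be read against these results, as that compound also differs elsewhere in its structure. Still open, going by these compounds, is whether bromo, methyl or methoxy at this position would match chloro, and whether a longer chain ending in an amine, or a carboxylic acid, would behave like aminomethyl.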